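This account rests on a few compounds, and the source may have more. Where it says the series, first, only, none or still open, it means among the compounds named here.

Measured in a functional assay on MCF7 cells (Homo sapiens) for cytotoxicity, read by MTT assay, with a stated time of 72 h; a higher number here means a weaker inhibitor, a lower number a stronger inhibitor:
compound 1 `COc1ccc(/C=N/NC(=O)Nc2cc3c(Nc4ccc(F)c(Cl)c4)ncnc3cc2O[C@H]2CCOC2)cc1`: 27300 nM
compound 2 `O=C(N/N=C/c1ccc(O)cc1O)Nc1cc2c(Nc3ccc(F)c(Cl)c3)ncnc2cc1O[C@H]1CCOC1`: 5350 nM

Of these two, compound 2 has the lower number, at 5350 nM. The next compound to consider is compound 3 `O=C(N/N=C/c1ccc(O)cc1)Nc1cc2c(Nc3ccc(F)c(Cl)c3)ncnc2cc1O[C@H]1CCOC1`, which has hydrogen in place of hydroxy on an aromatic carbon, turning 2,4-dihydroxyphenyl into 4-hydroxyphenyl: hydrogen in place of hydroxy on an aromatic carbon.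

Among the compounds with values here, only one measured step bears on this change, and only in part. a 5.1-fold lower number from compound 1 to compound 2 (0.71 log units; beyond the scatter) is modest, and it goes with 2,4-dihydroxyphenyl replacing 4-methoxyphenyl. That step adds the hydroxy in question but also replaces methoxy with hydroxy, and the data do not show how much of it belongs to each change. In structure, compound 3 differs from both measured compounds at this ring, so a value between theirs seems the plainest expectation. The removal should therefore give a higher number in this assay, by part of the size of the measured step, and the shift may not clear the scatter by much. The estimated step is a 2.2-fold higher number from compound 2 to compound 3 (0.35 log units; beyond the scatter). Compound 3 is expected at 12000 nM, with an estimated range of 4500 nM to 28000 nM.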

Compound 3, half-maximal inhibitory concentration: 910 nM
For compound 3 the middle estimate is 13-fold (1.12 log units) above the measured one; the whole stated range lies above it.
By their numbers in this assay, from the lowest: compound 3; then compound 2; then compound 1.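

Taking the hydroxy away from the position ortho to a large group and meta to a hydroxy group gives a 5.9-fold lower number from compound 2 to compound 3 (0.77 log units; beyond the scatter) in this assay, so the second hydroxy of 2,4-dihydroxyphenyl does not account for the lower number seen earlier with compound 2. The comparison that isolates the other change, hydrogen in place of methyl on an oxygen on an aromatic ring, gives a 30-fold lower number from compound 1 to compound 3 (1.48 log units; beyond the scatter), and among these three compounds the 4-hydroxyphenyl of compound 3 carries the lowest number, with the 2,4-dihydroxyphenyl of compound 2 lying above it and the 4-methoxyphenyl of compound 1 higher still. No measurement available here explains either step, so the two shifts stand as observations on this ring only.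

Still open, going by these compounds, is whether the hydroxy of 4-hydroxyphenyl has to be a hydroxy at all, since an amine, a fluorine or a longer chain on the oxygen, such as ethoxy, would separate that group from its neighbours. Equally open, on these data alone, is whether a group other than hydroxy, such as fluorine or methyl, on the carbon ortho to a large group would raise the number as the hydroxy of compound 2 does.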